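Adding an Acetamidophenyl Group: Expected Effect on Cytotoxicity

This account rests on a few compounds, and the source may have more. Where it says the series, first, only, none or still open, it means among the compounds named here.

Compound 1 `CC(C)N(Cc1cccc(OCCCCCC(=O)O)c1)C(=O)c1ccccc1` in an ADME assay on HepG2 cells (Homo sapiens) for cytotoxicity, read by CellTiter-Glo and resazurin assay, with a stated time of 72 h (on this read-out higher numbers stand for an effect only at larger amounts of compound and lower numbers for an effect already at smaller amounts), gives > 26000 nM; this value is a limit of the assay, not a number.
Compound 2 `COc1cc(OC)cc(-c2ccc(C(=O)N(Cc3cccc(OCCCCCC(=O)O)c3)C(C)C)cc2)c1` in this assay gives > 26000 nM, also a limit of the assay.
Compound 3 `CCOC(=O)CCCCCOc1cccc(CN(C(=O)c2ccccc2)C(C)C)c1` in this assay gives > 26000 nM, again a limit of the assay.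

Compound 3 thus stands only as a limit in this assay, as do the other two measured compounds. The step from compound 1 to compound 2, a step that the two limits leave unreadable from compound 1 to compound 2, and the step from compound 1 to compound 3, a step that the two limits leave unreadable from compound 1 to compound 3, cannot be sized, since both ends of each are limits. The change from compound 3 to compound 4 `CCOC(=O)CCCCCOc1cccc(CN(C(=O)c2ccc(-c3cccc(NC(C)=O)c3)cc2)C(C)C)c1` is 3-acetamidophenyl in place of hydrogen on an aromatic carbon. The nearest measured comparison is the step from compound 1 to compound 2, where a different aromatic group also entered on an aromatic carbon. The evidence the limit of > 26000 nM in this assay, at which 3 of the 3 values shown sit, shows every measured compound sitting at that limit. Going by the values given here, no step here is readable, so no direction or size can be drawn from the numbers alone, and compound 4 is expected to remain at the limit as well. The expected step that the limit leaves unreadable from compound 3 to compound 4 reflects an estimate of no change beyond the scatter. Compound 4 is estimated at 32000 nM, with a range from 15000 nM to 90000 nM.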

Compound 4, half-maximal effective concentration: > 26000 nM
Compound 4: only a limit was reported; the forecaster's own chance of this, stated with the estimate: 80%; the middle value lies beyond the limit too.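

Compound 3 and compound 4 each give only a limit in this assay, so no size or direction can be read for the change between them. The compounds shown leave open how far any of them lies past that limit, and whether any change in structure shifts the read-out.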